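The source may report more compounds than this note shows. Statements on the series, on what has been measured and on what is new or still open speak of the compounds shown alone.

Among the compounds with values here, compound 1, `COc1ccc(CS(=O)(=O)/C=C/c2c(OC)cccc2OC)cc1`, is the only compound in this set that gives a number in a functional assay on BT-20 cells (Homo sapiens) for antiproliferative activity, read by trypan blue exclusion; on this read-out lower numbers stand for stronger inhibition and higher numbers for weaker inhibition: there compound 1 gives 400 nM. Compound 3, `COc1ccc(CS(=O)(=O)/C=C/c2c(OC)cc(O)cc2OC)cc1`, carries a hydroxy in place of hydrogen on an aromatic carbon, and in this assay compound 3 gives only a limit of the assay, > 20000 nM. The step is an at least 50-fold higher number from compound 1 to compound 3 (1.69 log units; beyond the scatter).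

Compound 2, `COc1ccc(CS(=O)(=O)/C=C/c2cc(OC)c(OC)c(OC)c2)cc1`, has a different core, and the difference between the two cores is not broken down here. In this assay compound 2 gives only a limit of the assay, > 20000 nM. Compound 4, `COc1ccc(CS(=O)(=O)/C=C/c2cc(OC)c(OC)c(OC)c2)cc1O`, is not yet measured; it differs from compound 2 by a hydroxy in place of hydrogen on an aromatic carbon. This is the same kind of change as from compound 1 to compound 3, not the same: there the place was meta to two methoxy groups and para to a large group, here it is ortho to a methoxy group and meta to a large group.

Within the data shown here, the one measured instance of this kind of change, an at least 50-fold higher number from compound 1 to compound 3 (1.69 log units; beyond the scatter), went sharply toward weaker inhibition, and compound 2 already sits at the limit of > 20000 nM in this assay, at which 2 of the 3 values shown sit. The step from compound 2 to compound 4 is therefore expected to be small in this assay, a step that the limit leaves unreadable from compound 2 to compound 4, because compound 2 is already at the limit > 20000 nM. Compound 4 is expected to give 30000 nM in this assay, most likely reported as a limit, with a range from 8000 nM to 120000 nM.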

Compound 4, half-maximal inhibitory concentration: 7500 nM
Beside the measured number, compound 4's estimate is 4.0-fold (0.60 log units) above it; the whole stated range lies above it.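

In this assay, the hydroxy in place of hydrogen on an aromatic carbon gives an at least 2.6-fold lower number from compound 2 to compound 4 (0.42 log units; beyond the scatter), so the earlier sharp move toward weaker inhibition does not repeat on this core. Set side by side, the two steps show that the direction of this change does not carry over from one core to the other within this series: the same change on two cores in this assay, an at least 50-fold higher number (1.69 log units; beyond the scatter) from compound 1 to compound 3 and an at least 2.6-fold lower number (0.42 log units; beyond the scatter) from compound 2 to compound 4, at least 130-fold (2.12 log units) apart, beyond the scatter of two such steps. What this does not show is whether the core or the place of the hydroxy decides the direction, as the two pairs differ in both, and each step is bounded by a limit of the assay, so neither step has a known size.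

The compounds shown leave open whether a hydroxy placed as in the 3-hydroxy-4-methoxyphenyl of compound 4 would also lower the number on the core of compound 1, which would separate the effect of the core from that of the place. They also leave open whether an amine, a carboxylic acid or a longer chain such as ethoxy, set in the place of this hydroxy, would move the number in the same direction as the hydroxy does from compound 2 to compound 4.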